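Pentafluoroethyl for pentafluorosulfanyl on an anilide aryl ring

This account rests on a few compounds, and the source may have more. Where it says the series, first, only, none or still open, it means among the compounds named here.

Measured compounds:
compound 1, `CC(O)(COc1cc(C(F)(F)F)cc(C(F)(F)F)c1)C(=O)Nc1cccc(S(F)(F)(F)(F)F)c1`, 9300 nM
compound 2, `CC(O)(COc1cccc(S(F)(F)(F)(F)F)c1)C(=O)Nc1cc(C(F)(F)F)cc(C(F)(F)F)c1`, 5700 nM
compound 3, `CC(O)(COc1cccc(C(F)(F)C(F)(F)F)c1)C(=O)Nc1cc(C(F)(F)F)cc(C(F)(F)F)c1`, 8500 nM

All three were tested in a functional assay on DU-145 cells (Homo sapiens) for antiproliferative activity, read by propidium iodide staining, with a stated time of 96 h; a higher number here means a weaker inhibitor, a lower number a stronger inhibitor. Compound 1 and compound 2 are built from the same atoms joined differently; the difference between the two cores is not broken down here. Compound 3 arises from compound 2 by one change: a group of 7 heavy atoms (2 carbon, 5 fluorine; no ring) in place of a group of 6 heavy atoms (5 fluorine, 1 sulfur; no ring), on an aromatic carbon This change gave a 1.5-fold higher number from compound 2 to compound 3 (0.17 log units; within the scatter). The three measured values thus all lie close together.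

Compound 4, `CC(O)(COc1cc(C(F)(F)F)cc(C(F)(F)F)c1)C(=O)Nc1cccc(C(F)(F)C(F)(F)F)c1`, has not been measured. For the measured compounds named here, it arises from compound 1 by the same change, at a place described in the same words: a group of 7 heavy atoms (2 carbon, 5 fluorine; no ring) in place of a group of 6 heavy atoms (5 fluorine, 1 sulfur; no ring), on an aromatic carbon The step from compound 1 to compound 4 is therefore expected to resemble the one seen between compound 2 and compound 3 in this assay. Since that step is a 1.5-fold higher number from compound 2 to compound 3 (0.17 log units; within the scatter), the expected step from compound 1 to compound 4 in this assay is a 1.3-fold higher number from compound 1 to compound 4 (0.11 log units; within the scatter), which should also remain within the usual scatter. On this basis, compound 4 is estimated to give 12000 nM in this assay, with a range from 6000 nM to 25000 nM expected to cover most repeats. This expectation rests on a single prior instance of the change and on compound 1's own value of 9300 nM, so it is held loosely.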

Compound 4, half-maximal inhibitory concentration: 9800 nM
Compound 4: middle estimate off by 1.2-fold (0.09 log units), on the high side, within the range that was stated.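

In this assay, putting 1,1,2,2,2-pentafluoroethyl in place of pentafluorosulfanyl on the core of compound 1 gave a 1.1-fold higher number from compound 1 to compound 4 (0.02 log units; within the scatter), and the step agrees with the one seen earlier on the other core: the same change on two cores in this assay, a 1.5-fold higher number (0.17 log units; within the scatter) from compound 2 to compound 3 and a 1.1-fold higher number (0.02 log units; within the scatter) from compound 1 to compound 4, 1.4-fold (0.15 log units) apart, within the scatter of two such steps On these two cores, then, the change carries over with no detectable difference, and on each core the number stays within the scatter of its starting value. For the compounds shown here, this does not show that the two groups are interchangeable across the series, since it rests on only two pairs in a single assay, and steps this small could not reveal a modest dependence on the core; nor does it explain why the values stay so close.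

The compounds shown leave open whether the agreement would hold for other groups in that place, such as a nitrile, a chlorine atom, a tert-butyl group, an amine or a carboxylic acid. They also leave open whether the same change would behave alike on a core carrying a different chain in place of the hydroxyl-bearing linker, or in a read-out other than this assay.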